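Trimming ethoxy to methoxy at the assay limit

The compounds below may be only part of what the source reports. "The series", "measured", "known", "first", "only" and "open" are said of these compounds alone.

Compound 1 `COc1ccc(C[S+]([O-])c2ncccc2C(=O)Nc2ccncc2)c(OC)c1C` gives 0.12 h
Compound 2 `CCOc1cc(OC)ccc1C[S+]([O-])c1ncccc1C(=O)Nc1ccncc1` gives < 0.02 h

In an ADME assay (on this read-out lower numbers stand for a shorter-lived compound and higher numbers for a longer-lived compound), compound 2 stands at < 0.02 h as a limit of the assay, not a number. Compound 1 gives a true number, 0.12 h on the same read-out. Compound 3 `COc1ccc(C[S+]([O-])c2ncccc2C(=O)Nc2ccncc2)c(OC)c1` carries hydrogen in place of methyl on a saturated chain carbon bound to an oxygen on an aromatic ring, ethoxy to methoxy (hydrogen in place of methyl on a saturated chain carbon bound to an oxygen on an aromatic ring). For the measured compounds named here, no measured step shows this change, so only a small rise in this assay is expected, an estimated at least 2.0-fold higher number from compound 2 to compound 3 (0.30 log units; that floor lies within the scatter) and perhaps none beyond the scatter. Compound 3 is estimated at 0.04 h with a range of 0.02 h to 0.12 h on this read-out, and it may still report only a limit.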

Compound 3, half-life: < 0.02 h
Compound 3 gave a limit, no number; the forecaster's own chance of this, stated with the estimate: 30%; middle value at least 2.0-fold (0.30 log units) from the limit.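

Trimming ethoxy to methoxy leaves compound 3 at a limit of the assay as well, < 0.02 h in this assay. The step from ethoxy to methoxy cannot be read, because both compounds sit at the same limit: the limit of < 0.02 h in this assay, at which 2 of the 3 values shown sit.

Hydrogen in place of methyl on an aromatic carbon, by contrast, gives a readable step, an at least 6.0-fold lower number from compound 1 to compound 3 (0.77 log units; beyond the scatter).

Going by these compounds, how far apart compound 2 and compound 3 truly lie stays open. Also open, on these data alone, is what an ethyl group or a chlorine on that aromatic carbon would give in this assay.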